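Swapping one methoxy for fluorine on the aryl ring

The source may report more compounds than this note shows. Statements on the series, on what has been measured and on what is new or still open speak of the compounds shown alone.

Compound 1 `COc1ccccc1N1C(=O)C(C)SC1c1cccc(C(=O)NCCCCc2ccccc2)c1` gives 84% in a functional assay on SJSA-1 cells (Homo sapiens) for inhibition, read by CCK-8 assay, with a stated time of 72 h, tested at 1 uM; a lower number here means less inhibition, a higher number more inhibition at the concentration tested (going by the name of the read-out). Compound 2 `COc1cccc(OC)c1N1C(=O)CSC1c1cccc(C(=O)NCCCCc2ccccc2)c1` gives 72% in this assay, the lower of the two numbers, with compound 1 lying beyond the usual scatter above it. Compound 3 `COc1c(F)cccc1N1C(=O)CSC1c1cccc(C(=O)NCCCCc2ccccc2)c1` differs from compound 2 in one place: 3-fluoro-2-methoxyphenyl in place of 2,6-dimethoxyphenyl on an amide-type nitrogen in a ring. For the measured compounds named here, no measured step of this kind is available, so the expected step from compound 2 to compound 3 is a number 3 percentage points higher from compound 2 to compound 3 (within the scatter), a small change not clearly beyond the scatter. Compound 3 is therefore expected to reach 75% in this assay, within a range from 60% to 88%.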

Compound 3, a percentage reported as inhibition, at one concentration (the size of the read-out at that concentration, not a potency): 1%
The estimate for compound 3 lay 74 percentage points above the measured number; measured number outside the range, below it.
By their numbers in this assay, from the lowest: compound 3; then compound 2; then compound 1.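

In this assay, the aryl group on the amide-type nitrogen in a ring turns out to be a decisive place in this series: 3-fluoro-2-methoxyphenyl in place of 2,6-dimethoxyphenyl gives a number 71 percentage points lower from compound 2 to compound 3 (beyond the scatter). The earlier compounds shown here did not show this, as compound 1 and compound 2 differ in more than one place. No measurement shown explains the loss.

The change removes a methoxy and adds a fluorine together, so their separate contributions cannot be told apart. On these data alone, whether 2-methoxyphenyl alone, or an amine on that ring, would keep the inhibition on the core of compound 2 remains open.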